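Removing the acyl group from the ring nitrogen of compound 2

The compounds below may be only part of what the source reports. "The series", "measured", "known", "first", "only" and "open" are said of these compounds alone.

Compound 2 `CCCC(=O)N1c2ccccc2CCC1C(=O)Nc1cc(C(F)(F)F)cc(C(F)(F)F)c1` gives 15200 nM in a functional assay on MDA-MB-231 cells (Homo sapiens) for cytotoxicity, read by sulforhodamine B assay, with a stated time of 72 h (on this read-out higher numbers stand for weaker inhibition of growth and lower numbers for stronger inhibition of growth), the second highest of three numbers in the set. Compound 1 `O=C(Nc1cc(C(F)(F)F)cc(C(F)(F)F)c1)C1CCc2ccccc2N1C(=O)c1ccc(Cl)cc1` gives 2000 nM, and compound 3 `CC(=O)N1c2ccccc2CCC1C(=O)Nc1ccccc1O` gives 89600 nM. Compound 4 `O=C(Nc1cc(C(F)(F)F)cc(C(F)(F)F)c1)C1CCc2ccccc2N1` differs from compound 2 by hydrogen in place of propylcarbonyl on a nitrogen on an aromatic ring in a ring. Among the measured compounds shown here, the only measured step at this position is a 7.6-fold higher number from compound 1 to compound 2 (0.88 log units; beyond the scatter); it exchanges the group on the carbonyl but leaves the carbonyl in place, so no measured pair shows a free nitrogen here. Because a 7.6-fold higher number from compound 1 to compound 2 (0.88 log units; beyond the scatter) already lay beyond the scatter, removal of the whole acyl group is expected to move the number beyond the scatter as well, most likely upward. Compound 4 is therefore estimated at 30000 nM, with a range from 5000 nM to 150000 nM. The expected step is a 2.0-fold higher number from compound 2 to compound 4 (0.30 log units; within the scatter).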

Compound 4, concentration for 50% growth inhibition: 8270 nM
Beside the measured number, compound 4's estimate is 3.6-fold (0.56 log units) above it; low and high end bracket the measured number.
By their numbers in this assay, from the lowest: compound 1; then compounds 4 and 2 (each within the scatter of the next); then compound 3.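

Hydrogen in place of propylcarbonyl in this assay gives a 1.8-fold lower number from compound 2 to compound 4 (0.26 log units; within the scatter) and so leaves the two compounds unresolved, which means this acyl group can go without a readable change. Hydrogen in place of (4-chlorophenyl)carbonyl gives a 4.1-fold higher number from compound 1 to compound 4 (0.62 log units; beyond the scatter) and so separates the two, which means the outcome at this nitrogen depends on which acyl group leaves, not on the carbonyl alone. No evidence at hand accounts for either step.

As far as these compounds go, whether an unsubstituted benzoyl group or a longer acyl chain would read like compound 1 or like compound 4 remains open. So does the result of an ethyl group placed directly on the nitrogen, without a carbonyl.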